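The source may report more compounds than this note shows. Statements on the series, on what has been measured and on what is new or still open speak of the compounds shown alone.

Measured so far:
compound 1, `Nc1scc(CN2CCN(c3cccc(C(F)(F)F)c3)CC2)c1C(=O)c1ccc(Cl)cc1`, -72%;
compound 2, `Nc1scc(CN2CCN(c3ccc(C(F)(F)F)cc3)CC2)c1C(=O)c1cccc(C(F)(F)F)c1`, -27%.

In a functional assay on CHO cells with adenosine receptor A1 (Homo sapiens) as the target, read by cAMP accumulation and immunoassay, with a stated time of 6 min, tested at 1 uM (on this read-out higher numbers stand for a weaker effect at the one concentration tested and lower numbers for a stronger effect), compound 2 gives -27%, the highest of the two numbers, that is, the weaker effect; compound 1 lies well below it, a gap beyond the usual scatter. Compound 3, `Nc1scc(CN2CCN(c3cccc(F)c3)CC2)c1C(=O)c1cccc(C(F)(F)F)c1`, differs from compound 2 in one place: 3-fluorophenyl in place of 4-(trifluoromethyl)phenyl on an amine nitrogen in a ring. Within the data shown here, with no measured pair sharing exactly this change, the direction is uncertain; a modest move toward a stronger effect is expected, a number 18 percentage points lower from compound 2 to compound 3 (beyond the scatter). Compound 3 is thus estimated at -45%, between -75% and -15%.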

Compound 3, a percentage reported as activity, at one concentration (the size of the read-out at that concentration, not a potency): -35%
For compound 3 the middle estimate is 10 percentage points below the measured one; measured number inside the range.
By their numbers in this assay, from the lowest: compound 1; then compounds 3 and 2 (each within the scatter of the next).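

With 3-fluorophenyl in place of 4-(trifluoromethyl)phenyl on the amine nitrogen in the ring, this assay shows a number 8 percentage points lower from compound 2 to compound 3 (within the scatter) and so does not separate the two compounds. On this one pair, the group on that nitrogen can change in both its substituent and where that substituent sits without a difference beyond the scatter. Nothing measured here offers a reason for this result.

Going by these compounds, this single step changes both features at once, so their separate contributions stay open. Also open, on these data alone, is how a plain phenyl group, or a phenyl group carrying a carboxylic acid, would read at this nitrogen.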